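This account rests on a few compounds, and the source may have more. Where it says the series, first, only, none or still open, it means among the compounds named here.

In a functional assay on HCT-116 cells (Homo sapiens) for antiproliferative activity, read by MTT assay, with a stated time of 24 h (on this read-out higher numbers stand for weaker inhibition and lower numbers for stronger inhibition), compound 3 `COc1cc(OC)c(-c2coc3cc(OCC(=O)c4cccc(C(F)(F)F)c4)ccc3c2=O)cc1OC` gives > 10000 nM, which is a limit of the assay and not a number. On the same shared core, compound 1 `C=CCOc1ccc2c(=O)c(-c3cc(OC)c(OC)cc3OC)coc2c1` gives 6600 nM and compound 2 `COc1cc(OC)c(-c2coc3cc(OCc4ccccc4)ccc3c2=O)cc1OC` gives 2280 nM. Compound 4 `COc1cc(OC)c(-c2coc3cc(OCc4ccccc4C)ccc3c2=O)cc1OC` brings one change from compound 3: 2-methylphenyl in place of (3-(trifluoromethyl)phenyl)carbonyl on a saturated chain carbon bound to an oxygen on an aromatic ring. Here, 2-methylphenyl takes the place of (3-(trifluoromethyl)phenyl)carbonyl on a saturated chain carbon bound to an oxygen on an aromatic ring. Among the compounds with values here, two measured steps bear on this. Swapping phenyl for that same carbonyl group gave an at least 4.3-fold higher number from compound 2 to compound 3 (0.64 log units; beyond the scatter), while phenyl in place of vinyl gave a 2.9-fold lower number from compound 1 to compound 2 (0.46 log units; beyond the scatter). A step of similar size back toward stronger inhibition is therefore expected, namely an at least 4.0-fold lower number from compound 3 to compound 4 (0.60 log units; beyond the scatter). For compound 4 the estimate is 2500 nM, with an expected range of 900 nM to 7000 nM.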

Compound 4, half-maximal inhibitory concentration: 2900 nM
Beside the measured number, compound 4's estimate is 1.2-fold (0.06 log units) below it, within the range that was stated.
By their numbers in this assay, from the lowest: compounds 2 and 4 (each within the scatter of the next); then compound 1. At a limit, above all of these: compound 3.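

In this assay, adding a methyl to the phenyl ring makes no difference that can be told apart, with a 1.3-fold higher number from compound 2 to compound 4 (0.10 log units; within the scatter). The 2-methylphenyl group still gives stronger inhibition than vinyl, with a 2.3-fold lower number from compound 1 to compound 4 (0.36 log units; beyond the scatter), and than the (3-(trifluoromethyl)phenyl)carbonyl group, with an at least 3.4-fold lower number from compound 3 to compound 4 (0.53 log units; beyond the scatter). The value for compound 3 is a limit of the assay, so that last step gives only a minimum size: the limit of > 10000 nM in this assay, at which 1 of the 4 values shown sits.

From the compounds shown here alone, compound 3 carries its carbonyl and trifluoromethyl together, so which of them goes with its weaker result stays open. How an amine or a carboxylic acid on the phenyl ring would read is also unknown.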